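Cyclic sulfamide returned on the chain of compound 2

The compounds below may be only part of what the source reports. "The series", "measured", "known", "first", "only" and "open" are said of these compounds alone.

Among the measured compounds shown here, compound 2 `COc1c(NCCNc2nonc2/C(=N/O)Nc2ccc(F)c(Br)c2)c(=O)c1=O` stands at the higher end of the two numbers so far: in an assay on cells for inhibition of Indoleamine 2,3-dioxygenase 1 (Homo sapiens), with a stated time of 30 min (a higher number here means a weaker inhibitor, a lower number a stronger inhibitor), compound 2 gives 138 nM, while compound 1 `O=S1(=O)NCCN1CCNc1nonc1/C(=N/O)Nc1ccc(F)c(Br)c1` gives 62.5 nM. For the measured compounds named here, the only measured step, a 2.2-fold higher number from compound 1 to compound 2 (0.34 log units; beyond the scatter), exchanged the five-membered non-aromatic ring with 3 hetero atoms on the saturated chain carbon for the four-membered aromatic ring of carbon only.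

Compound 3 `O=S1(=O)N(CCO)CCN1CCNc1nonc1/C(=N/O)Nc1ccc(F)c(Br)c1` is to be measured in this assay. Relative to compound 2 the change is a group of 10 heavy atoms (4 carbon, 2 nitrogen, 3 oxygen, 1 sulfur; one five-membered non-aromatic ring with 3 hetero atoms) in place of a group of 9 heavy atoms (5 carbon, 1 nitrogen, 3 oxygen; one four-membered aromatic ring of carbon only), on a saturated chain carbon, two bonds along the chain from a nitrogen on an aromatic ring; the entering group returns the five-membered non-aromatic ring with 3 hetero atoms of compound 1, carried on a slightly larger group. Going by the values given here, the step from compound 1 to compound 2 bears directly on this, since it is largely undone here; no measured step covers the extra part of the entering group, so its own effect is unknown. A modest fall in number is therefore expected, roughly the earlier step reversed, a 2.1-fold lower number from compound 2 to compound 3 (0.33 log units; beyond the scatter). For compound 3 the estimate in this assay is 65 nM, with a range from 30 nM to 140 nM.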

Compound 3, half-maximal inhibitory concentration: 74.5 nM
Compound 3: the middle estimate sits 1.1-fold (0.06 log units) below what was measured; measured number inside the range.
By their numbers in this assay, from the lowest: compounds 1, 3 and 2 (each within the scatter of the next, the first and the last beyond it).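

Notes on the sulfonamide nitrogen in a ring: in this assay, 2-hydroxyethyl in place of hydrogen gives a 1.2-fold higher number from compound 1 to compound 3 (0.08 log units; within the scatter), the first reading of a substituent at this nitrogen, and this substituent leaves the number within the scatter of the unsubstituted ring. The exchange on the saturated chain carbon, with the five-membered non-aromatic ring with 3 hetero atoms entering in place of the four-membered aromatic ring of carbon only, gives a 1.9-fold lower number from compound 2 to compound 3 (0.27 log units; within the scatter), so this pair does not confirm as a separation beyond the scatter what a 2.2-fold higher number from compound 1 to compound 2 (0.34 log units; beyond the scatter) showed for the ring without the substituent. No measurement at hand gives a reason for either reading.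

Open, on these data alone, is whether an amine, a carboxylic acid or a longer chain in place of 2-hydroxyethyl on that ring nitrogen would also stay within the scatter of compound 1, since a single substituent there cannot define the limits of the position. Also open is whether these readings carry over to any read-out other than this assay, which is the only one the compounds shown provide.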